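This account rests on a few compounds, and the source may have more. Where it says the series, first, only, none or still open, it means among the compounds named here.

Measured so far:
compound 1 `CC(C)[C@@H](C(=O)N1CCC[C@H]1C(=O)N[C@@H](CCCNC(=N)N)C(=O)CF)N(C)C(=O)OCc1ccccc1` — > 20000 nM
compound 2 `CC(C)[C@H](NC(=O)c1ccccc1)C(=O)N1CCC[C@H]1C(=O)N[C@@H](CCCNC(=N)N)C(=O)CF` — 660 nM
compound 3 `COc1ccc(C(=O)N[C@H](C(=O)N2CCC[C@H]2C(=O)N[C@@H](CCCNC(=N)N)C(=O)CF)C(C)C)cc1` — 1670 nM

Within the data shown here, in a functional assay on OCI-Ly3 cells (Homo sapiens) for inhibition, read by CellTiter-Glo, with stated times of 48 h and 96 h (on this read-out lower numbers stand for stronger inhibition of growth and higher numbers for weaker inhibition of growth), compound 1 gives only a limit, > 20000 nM, the one value of the three that sits at the limit of > 20000 nM in this assay, at which 1 of the 3 values shown sits. Compound 2 gives 660 nM and compound 3 gives 1670 nM in this assay.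

Compound 4 `CC(C)[C@H](NC(=O)C1CCCCC1)C(=O)N1CCC[C@H]1C(=O)N[C@@H](CCCNC(=N)N)C(=O)CF` is not yet measured. It differs from compound 1 as follows: (cyclohexylcarbonyl)amino in place of (benzyloxycarbonyl)(methyl)amino on a saturated chain carbon bound to a carbonyl carbon and a saturated chain carbon.

Among the measured compounds shown here, two measured steps bear on this: an at least 30-fold lower number from compound 1 to compound 2 (1.48 log units; beyond the scatter) and an at least 11-fold lower number from compound 1 to compound 3 (1.07 log units; beyond the scatter). Both replace the same group at the same place with an amide and both are large; between the two amides, a 2.5-fold higher number from compound 2 to compound 3 (0.40 log units; beyond the scatter). A large drop is therefore expected in this assay, of a size comparable to those two steps. Compound 4 is expected at 1500 nM, within 400 nM to 6000 nM. The expected step is an at least 13-fold lower number from compound 1 to compound 4 (1.12 log units; beyond the scatter).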

Compound 4, concentration for 50% growth inhibition: 940 nM
For compound 4 the middle estimate is 1.6-fold (0.20 log units) above the measured one; low and high end bracket the measured number.
By their numbers in this assay, from the lowest: compounds 2, 4 and 3 (each within the scatter of the next, the first and the last beyond it). At a limit, above all of these: compound 1.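

In this assay, an aromatic ring on the amide carbonyl is not needed at this position: cyclohexyl in place of phenyl gives a 1.4-fold higher number from compound 2 to compound 4 (0.15 log units; within the scatter), and cyclohexyl in place of 4-methoxyphenyl gives a 1.8-fold lower number from compound 3 to compound 4 (0.25 log units; within the scatter), both within the scatter. The gain from the amide replacement therefore also holds with a non-aromatic ring, at an at least 21-fold lower number from compound 1 to compound 4 (1.32 log units; beyond the scatter). The value of compound 1 is a limit: the limit of > 20000 nM in this assay, at which 1 of the 4 values shown sits.

The compounds shown do not separate the role of the amide hydrogen from that of the carbonyl-bound ring, since every amide here carries both. Also open, going by these compounds, is how a small acetyl group, or an amine on the cyclohexyl ring, would read.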